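Adding a Third Methoxy to a Styryl Butenolide

The source may hold more compounds than are shown below. What is called first, only, known or untested is meant among the compounds shown, and "the series" means these compounds.

Measured compounds:
compound 1, `COc1ccc(/C=C/C2(C)C=CC(=O)O2)c(OC)c1`: 57500 nM
compound 2, `COc1ccc(/C=C/C2(C)C=CC(=O)O2)cc1OC`: 927000 nM
compound 3, `COc1cc(/C=C/C2(C)C=CC(=O)O2)cc(OC)c1OC`: 390000 nM

In a functional assay on HT-29 cells (Homo sapiens) for inhibition, read by sulforhodamine B assay, with a stated time of 48 h (on this read-out higher numbers stand for weaker inhibition of growth and lower numbers for stronger inhibition of growth), compound 1 gives 57500 nM, the lowest of the three numbers. Compound 2 gives 927000 nM and compound 3 gives 390000 nM in this assay. Compounds 1 and 2 share the same atoms joined differently; the difference between the two cores is not broken down here.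

One change is seen twice. From compound 2 to compound 3 it is methoxy in place of hydrogen on an aromatic carbon and it brought a 2.4-fold lower number from compound 2 to compound 3 (0.38 log units; beyond the scatter). The unmeasured compound 4, `COc1cc(OC)c(/C=C/C2(C)C=CC(=O)O2)c(OC)c1`, arises from compound 1 by methoxy in place of hydrogen on an aromatic carbon. The two placements are not identical: in compound 3 the new methoxy sits ortho to a methoxy group, meta to a group of 9 heavy atoms and meta to a methoxy group, whereas in compound 4 it sits ortho to a group of 9 heavy atoms and meta to two methoxy groups. It is therefore the same kind of change, not the same change.

Resting on the step from compound 2 to compound 3, the account expects a modest drop of similar size for compound 4, a 1.9-fold lower number from compound 1 to compound 4 (0.28 log units; within the scatter), with wider uncertainty because the surroundings differ. Compound 4 is estimated at 30000 nM in this assay, expected between 8000 nM and 120000 nM.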

Compound 4, concentration for total growth inhibition: 127000 nM
Compound 4: middle estimate off by 4.2-fold (0.63 log units), on the low side; the measured number lies above the stated range.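

In this assay, methoxy in place of hydrogen on an aromatic carbon brought a 2.2-fold higher number from compound 1 to compound 4 (0.34 log units; beyond the scatter), whereas the same kind of change had brought a 2.4-fold lower number from compound 2 to compound 3 (0.38 log units; beyond the scatter). Set side by side, the two steps point in opposite directions and do not agree: the same change on two cores in this assay, a 2.4-fold lower number (0.38 log units; beyond the scatter) from compound 2 to compound 3 and a 2.2-fold higher number (0.34 log units; beyond the scatter) from compound 1 to compound 4, 5.2-fold (0.72 log units) apart, beyond the scatter of two such steps This shows that, within these compounds, neither the direction nor the size of the step carries over from one core to the other, although it does not show what sets the two apart, since each step is seen only once and the two differ both in the core and in where the new methoxy sits, which in compound 4 is ortho to a group of 9 heavy atoms and meta to two methoxy groups.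

All four compounds shown carry only methoxy groups on the aromatic ring, so it remains open whether an amine, a carboxylic acid or a longer chain such as ethoxy on that ring would follow the step seen on one core, the step seen on the other, or neither. As far as these compounds go, it also remains open how a new methoxy would behave at other free positions of the ring on either core.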